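This account rests on a few compounds, and the source may have more. Where it says the series, first, only, none or still open, it means among the compounds named here.

Compound 1, `C#CCOc1cccc(/C=C/C(=O)Nc2cc(C(=O)c3cc(OC)c(OC)c(OC)c3)ccc2OC)c1`, is a member of a small set built on a shared core. In a functional assay on PC-3 cells (Homo sapiens) for cytotoxicity, read by MTT assay, with a stated time of 72 h (a higher number here means a weaker inhibitor, a lower number a stronger inhibitor), compound 1 gives 13100 nM, the highest of the three numbers measured, though all three sit close together. Compound 2, `COc1ccc(C(=O)c2cc(OC)c(OC)c(OC)c2)cc1NC(=O)/C=C/c1cccc(OC(F)(F)F)c1`, gives 7700 nM, and compound 3, `COc1ccc(C(=O)c2cc(OC)c(OC)c(OC)c2)cc1NC(=O)/C=C/c1ccc(F)c(F)c1`, gives 8300 nM; the steps of a 1.7-fold lower number from compound 1 to compound 2 (0.23 log units; within the scatter) and a 1.6-fold lower number from compound 1 to compound 3 (0.20 log units; within the scatter) stay within the scatter. Compound 4, `C#CCOc1cccc(/C=C/C(=O)Nc2cc(C(=O)c3cc(OC)c(OC)c(OC)c3)cc(OC)c2OC)c1`, differs from compound 1 by methoxy in place of hydrogen on an aromatic carbon. The measured steps all alter the phenyl ring at the far end of the chain, not the ring that is changed here, so they bear only loosely on this step; they show that small changes in this set have not moved the number beyond the scatter. Compound 4 is therefore expected to stay close to compound 1, with an estimated 13000 nM, in a range from 5500 nM to 32000 nM, which means an expected step of a 1.0-fold lower number from compound 1 to compound 4 (0.00 log units; within the scatter).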

Compound 4, half-maximal inhibitory concentration: 10100 nM
For compound 4 the middle estimate is 1.3-fold (0.11 log units) above the measured one; low and high end bracket the measured number.
By their numbers in this assay, from the lowest: compounds 2, 3, 4 and 1 (each within the scatter of the next).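

In this assay methoxy in place of hydrogen on this aromatic carbon, ortho to a methoxy group and meta to two large groups, gives a 1.3-fold lower number from compound 1 to compound 4 (0.11 log units; within the scatter) and stays within the scatter. Unlike the earlier steps, which altered the phenyl ring at the far end of the chain, this one shows that the number also holds when this other ring gains a methoxy. No measured evidence accounts for this result.

One methoxy says little about this carbon in general. Going by these compounds, whether an amine or a carboxylic acid there would move the number beyond the scatter stays open.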